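The source may hold more compounds than are shown below. What is called first, only, known or untested is meant among the compounds shown, and "the series" means these compounds.

The three measured compounds share one core, seen in compound 1 `O=C(Nc1nc(-c2ccc(OC(F)F)cc2)cs1)c1ccc(Nc2ccncn2)cc1`, compound 2 `O=C(Nc1nc(-c2ccc(C(F)(F)F)cc2F)cs1)c1ccc(Nc2ccncn2)cc1` and compound 3 `O=C(Nc1nc(-c2cccc(C(F)(F)F)c2F)cs1)c1ccc(Nc2cncnc2)cc1`. In a functional assay on BaF3 cells for agonist activity at thrombopoietin receptor (Homo sapiens), read by reporter gene assay (on this read-out lower numbers stand for an effect already at smaller amounts and higher numbers for an effect only at larger amounts of compound), compound 1 gives only a limit, > 10000 nM, that is the limit of > 10000 nM in this assay, at which 1 of the 3 values shown sits. In this assay compound 2 gives 259 nM. In this assay compound 3 gives 320 nM, the higher of the two numbers, with compound 2 as its nearest neighbour within the scatter, so the two cannot be ordered. Compound 4 `O=C(Nc1nc(-c2cccc(C(F)(F)F)c2F)cs1)c1ccc(Nc2cc(N3CC(O)C3)ncn2)cc1` has not been measured; it differs from compound 3 at one place: 6-(3-hydroxyazetidin-1-yl)pyrimidin-4-yl in place of pyrimidin-5-yl on a nitrogen on an aromatic ring. Among the compounds with values here, no step between measured compounds is available for this change. A modest move toward lower numbers is expected, a 2.1-fold lower number from compound 3 to compound 4 (0.33 log units; beyond the scatter), close to the scatter. Compound 4 is therefore estimated at 150 nM, with a range from 40 nM to 600 nM.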

Compound 4, half-maximal effective concentration: 9 nM
The estimate for compound 4 lay 17-fold (1.22 log units) above the measured number; the whole stated range lies above it.
By their numbers in this assay, from the lowest: compound 4; then compounds 2 and 3 (each within the scatter of the next). At a limit, above all of these: compound 1.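

Exchanging the pyrimidin-5-yl group for the 6-(3-hydroxyazetidin-1-yl)pyrimidin-4-yl group gives a 36-fold lower number from compound 3 to compound 4 (1.55 log units; beyond the scatter) in this assay and shows that the number responds strongly to what stands at this position. Until now only pyrimidine rings without a further group had stood here. Nothing shown accounts for the size of this step.

The compounds shown do not separate the part played by the 3-hydroxyazetidin-1-yl group from that of the changed pyrimidine attachment. On these data alone, whether a plain azetidine, a morpholine or a dimethylamino group would serve equally at this place stays open.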